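The compounds below may be only part of what the source reports. "The series", "measured", "known", "first", "only" and "open" are said of these compounds alone.

Measured so far:
- compound 1, `Oc1ccc(-c2cc(-c3ccc(F)cc3)cc(-c3ccccc3O)n2)cc1`, > 50000 nM in a functional assay on T47D cells (Homo sapiens) for inhibition; on this read-out lower numbers stand for stronger inhibition and higher numbers for weaker inhibition 
- compound 2, `Oc1cccc(-c2cc(-c3cccc(F)c3)cc(-c3cccc(O)c3)n2)c1`, 21300 nM 
- compound 3, `Oc1cccc(-c2cc(-c3ccc(F)cc3)cc(-c3cccc(O)c3)n2)c1`, 6870 nM 

For the measured compounds named here, the value of compound 1 is a limit of this assay, not a number; it is the one value that sits at the limit of > 50000 nM in this assay, at which 1 of the 3 values shown sits. Among the two numbers shown, compound 3 gives the lower one; from compound 2 to compound 3 the step is a 3.1-fold lower number from compound 2 to compound 3 (0.49 log units; beyond the scatter), and that step changes only the fluorophenyl group.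

Compound 4, `Oc1ccc(-c2cc(-c3ccc(F)cc3)cc(-c3cccc(O)c3)n2)cc1`, differs from compound 3 in another place: 4-hydroxyphenyl in place of 3-hydroxyphenyl on an aromatic carbon. No measured step moves a hydroxyphenyl group, so the one step shown, from compound 2 to compound 3, does not bear on this change directly. Going by the values given here, compound 1 also carries a 4-hydroxyphenyl, but its second hydroxyphenyl differs from that of compound 4 as well, so its limit gives no step to read.

Among the compounds with values here, with no comparable step measured, the expectation for compound 4 is a number near that of compound 3, the estimated step being a 1.5-fold higher number from compound 3 to compound 4 (0.16 log units; within the scatter). The estimate for compound 4 in this assay is 10000 nM, in the range 3000 nM to 35000 nM.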

Compound 4, half-maximal inhibitory concentration: 5000 nM
The estimate for compound 4 lay 2.0-fold (0.30 log units) above the measured number; the measured number falls inside the stated range.
By their numbers in this assay, from the lowest: compounds 4 and 3 (each within the scatter of the next); then compound 2. At a limit, above all of these: compound 1.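

At this place on the shared core, next to the ring nitrogen, the two hydroxyphenyl isomers are not told apart in this assay, and 4-hydroxyphenyl serves as well as 3-hydroxyphenyl: a 1.4-fold lower number from compound 3 to compound 4 (0.14 log units; within the scatter). For the compounds shown here, the 2-hydroxyphenyl group is the first hydroxyphenyl change to go beyond the scatter, with 3-hydroxyphenyl in its place giving an at least 10-fold lower number from compound 1 to compound 4 (1.00 log units; beyond the scatter). The value of compound 1 is a limit of the assay, not a number, so the true size of this step stays unknown: the limit of > 50000 nM in this assay, at which 1 of the 4 values shown sits.

On these data alone, whether a hydroxyphenyl group is needed at either place remains open, and a methoxyphenyl, an aminophenyl or a carboxylic acid there would test it. Also open, as far as these compounds go, is how far the 2-hydroxyphenyl result carries over to a partner other than the 4-hydroxyphenyl of compound 1.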